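Compound 2 to compound 3: a change on the carbonyl carbon

The source may hold more compounds than are shown below. What is called first, only, known or untested is meant among the compounds shown, and "the series" means these compounds.

For the measured compounds named here, in an ADME assay for permeability, using PAMPA (a lower number here means that the compound crosses the layer more slowly, a higher number that the compound crosses the layer faster), compound 2 `O=C(Nc1cccc(-c2nc3ccccc3s2)c1)c1cnccc1Cl` gives 732 10^-6 cm/s, the lower end of the two numbers so far, though within the scatter of compound 1 `CC(Cl)C(=O)Nc1cccc(-c2nc3ccccc3s2)c1`, which gives 769 10^-6 cm/s. Going by the values given here, the only measured step, a 1.1-fold lower number from compound 1 to compound 2 (0.02 log units; within the scatter), exchanged the group on the carbonyl carbon without moving the number. Compound 3 `O=C(Nc1cccc(-c2nc3ccccc3s2)c1)c1cnc(Cl)s1` differs from compound 2 by 2-chloro-1,3-thiazol-5-yl in place of 4-chloropyridin-3-yl on a carbonyl carbon, again an exchange at that carbonyl carbon. Because a 1.1-fold lower number from compound 1 to compound 2 (0.02 log units; within the scatter) stayed within the scatter, compound 3 is expected to show no step beyond it, a 1.0-fold lower number from compound 2 to compound 3 (0.00 log units; within the scatter). The estimate for compound 3 is 730 10^-6 cm/s, with a range from 450 10^-6 cm/s to 1100 10^-6 cm/s.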

Compound 3, apparent permeability: 133 10^-6 cm/s
The estimate for compound 3 lay 5.5-fold (0.74 log units) above the measured number; the whole stated range lies above it.
By their numbers in this assay, from the lowest: compound 3; then compounds 2 and 1 (each within the scatter of the next).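

In this assay this carbonyl carbon turns out not to be indifferent to its group: 2-chloro-1,3-thiazol-5-yl in place of 4-chloropyridin-3-yl gives a 5.5-fold lower number from compound 2 to compound 3 (0.74 log units; beyond the scatter) and, in place of 1-chloroethyl, a 5.8-fold lower number from compound 1 to compound 3 (0.76 log units; beyond the scatter). The flat step seen earlier therefore held only for those two groups, not for every exchange at this place. Nothing available explains the step.

As far as these compounds go, whether the five-membered ring as such or its chlorine carries the step stays open. A methyl or an amine in place of that chlorine would bear on this.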